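Azetidine N-methyl to N-hydrogen: expected clearance

A few compounds are considered here, and "the series" means these few. Any claim that something is new, unique, unknown or untested is made for them only; others in the source may bear on it.

Measured so far in an ADME assay on liver for metabolic stability, with Liver microsome (Homo sapiens) as the target, read by LC-MS, using microsomes, with a stated time of 5 h; on this read-out lower numbers stand for slow clearance and higher numbers for fast clearance:
- Compound 1, `C[C@]1(O)C[C@@](c2ccnc(C(F)(F)F)c2)([C@H](O)c2ccccn2)C1`, gives 66.7 mL/min/kg.
- Compound 2, `CN1CC(c2ccc(C(F)(F)F)cc2)(C(O)c2ccccn2)C1`, gives 50 mL/min/kg.
- Compound 3, `O[C@H](c1ccccn1)[C@]1(c2cc(C(F)(F)F)ccn2)C[C@H](O)C1`, gives 33.3 mL/min/kg.

Compound 2 stands second highest of the three numbers. Its nearest neighbour is compound 1, whose number is slightly higher; compound 3 is furthest, with a somewhat lower number. Going by the values given here, both gaps lie within the usual scatter of repeated measurements, so the three compounds are not distinguished from one another on this read-out, and no compound can be called the most or least stable.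

The next compound, compound 4, `OC(c1ccccn1)C1(c2ccc(C(F)(F)F)cc2)CNC1`, differs from compound 2 in one place: hydrogen in place of methyl on an amine nitrogen in a ring.

Among the compounds with values here, no measured pair in this set differs in this way, so the size of the step is not anchored by a directly comparable step. The step of a 1.4-fold lower number from compound 2 to compound 4 (0.15 log units; within the scatter) is expected to be small, towards a lower number, and not clearly beyond the scatter. Compound 4 is expected to give about 35 mL/min/kg, within the range 15 mL/min/kg to 70 mL/min/kg.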

Compound 4, clearance: 33.3 mL/min/kg
For compound 4 the middle estimate is 1.1-fold (0.02 log units) above the measured one; low and high end bracket the measured number.
By their numbers in this assay, from the lowest: compounds 3, 4, 2 and 1 (each within the scatter of the next).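

In this assay, going by these compounds alone, the only one-place comparison gives a 1.5-fold lower number from compound 2 to compound 4 (0.18 log units; within the scatter), so hydrogen in place of methyl on this amine nitrogen in a ring does not separate the two compounds on this read-out. Within the data shown here, at this position, the methyl can therefore be lost without a change that can be distinguished from repeat-measurement noise, and the single pair supports no wider rule about the nitrogen. Nothing available bears on the reason for this result.

Going by these compounds, whether a larger group on the same nitrogen, such as an acetyl group or a longer alkyl chain, would give a step beyond the scatter remains open. Also open, on these data alone, is whether the same change would behave alike with the other aryl groups or on the other cores.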